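The source may report more compounds than this note shows. Statements on the series, on what has been measured and on what is new or still open speak of the compounds shown alone.

Measured so far:

Compound 1, `CCOC(=O)c1sc(-c2cccc(NC(=O)c3ccc(C(F)(F)F)cc3)c2)nc1Nc1ccc(N2CCN(C)CC2)cc1`: 18.4%
Compound 2, `CCOC(=O)c1sc(-c2cccc(NC(=O)c3ccc(F)cc3)c2)nc1Nc1ccc(N2CCN(C)CC2)cc1`: 3.53%
Compound 3, `CCOC(=O)c1sc(-c2cccc(NC(=O)c3ccccc3)c2)nc1Nc1ccc(N2CCN(C)CC2)cc1`: 77.1%

In a functional assay on Ramos cells (Homo sapiens) for antiproliferative activity, read by CCK-8 assay, with a stated time of 72 h, tested at 40 uM (a lower number here means less inhibition, a higher number more inhibition at the concentration tested (going by the name of the read-out)), compound 3 gives 77.1%, the highest of the three numbers; both of its steps to the others are beyond the scatter, so it stands clearly apart. Compound 4, `CCOC(=O)c1sc(-c2cccc(NC(=O)c3ccc(Cl)cc3)c2)nc1Nc1ccc(N2CCN(C)CC2)cc1`, has not yet been measured. It differs from compound 3 in one place: chloro in place of hydrogen on an aromatic carbon.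

Two of the measured steps bear on this change, since each of them removes a group from the same aromatic carbon that compound 4 fills again. a number 73.6 percentage points higher from compound 2 to compound 3 (beyond the scatter), and a number 58.7 percentage points higher from compound 1 to compound 3 (beyond the scatter). Both groups, fluoro and trifluoromethyl, sat at that position with far lower inhibition than the unsubstituted compound 3. A chloro group entering at the same position therefore is expected to move the number in the opposite direction, downward, by a large step in this assay, beyond the scatter.

Compound 4 is thus expected to give about 18%, within a range from 0% to 55%, which corresponds to an expected step of a number 59.1 percentage points lower from compound 3 to compound 4 (beyond the scatter).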

Compound 4, a percentage reported as inhibition, at one concentration (the size of the read-out at that concentration, not a potency): 46.9%
The estimate for compound 4 lay 28.9 percentage points below the measured number; measured number inside the range.
By their numbers in this assay, from the lowest: compound 2; then compound 1; then compound 4; then compound 3.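

In this assay chloro is a third group at this position that gives less inhibition than hydrogen, with a number 30.2 percentage points lower from compound 3 to compound 4 (beyond the scatter). Yet the position does not respond to all three groups alike: chloro in place of fluoro gives a number 43.4 percentage points higher from compound 2 to compound 4 (beyond the scatter), and chloro in place of trifluoromethyl gives a number 28.5 percentage points higher from compound 1 to compound 4 (beyond the scatter), so chloro keeps a good part of the inhibition that the other two groups lose. No measurement available here bears on why these groups differ.

The compounds shown leave open whether a methoxy group, an amine or a carboxylic acid at this position would also fall short of hydrogen. They also leave open how chloro would read on another carbon of this ring.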